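Pyridin-2-yl for Neopentyl: Expected Stability of Compound 3

The source may report more compounds than this note shows. Statements on the series, on what has been measured and on what is new or still open speak of the compounds shown alone.

Compound 1 `CC(C)CCn1nc(-c2cccs2)c(O)c(C2=NS(=O)(=O)c3cc(NS(=O)(=O)C4CC4)ccc3N2)c1=O`: > 1 h
Compound 2 `CC(C)(C)CCn1nc(-c2cccs2)c(O)c(C2=NS(=O)(=O)c3cc(NS(C)(=O)=O)ccc3N2)c1=O`: > 1 h

In an in vitro ADME assay on microsomes from liver (Homo sapiens) for metabolic stability, tested at 5 uM (a higher number here means that the compound lasts longer, a lower number that the compound disappears faster), compound 1 gives > 1 h, which is a limit of the assay rather than a number. In this assay compound 2 gives > 1 h, also a limit. Compound 2 therefore stands at the limit of > 1 h in this assay, at which 2 of the 2 values shown sit. Compound 3 `CS(=O)(=O)Nc1ccc2c(c1)S(=O)(=O)N=C(c1c(O)c(-c3cccs3)nn(Cc3ccccn3)c1=O)N2` differs from compound 2 by pyridin-2-yl in place of neopentyl on a saturated chain carbon bound to an aromatic nitrogen. Within the data shown here, no measured pair shows this change, so its size cannot be read from the data. The step is expected to be small, a step that the limit leaves unreadable from compound 2 to compound 3, with no direction beyond the scatter. Compound 3 is thus expected to give 1.5 h in this assay, within 0.5 h to 4 h.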

Compound 3, half-life: > 1 h
Compound 3 was reported as a limit (the forecaster's own chance of this, stated with the estimate: 60%); the middle value is on the limit's open side.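

In this assay compound 3 gives > 1 h, which is a limit of the assay. Among these compounds, no step from compound 2 to compound 3 can be read from this: the limit of > 1 h in this assay, at which 3 of the 3 values shown sit. On these data alone, the actual half-lives of compounds 1, 2 and 3 remain open, as does the size of the change from neopentyl to pyridin-2-yl.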